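Trifluoromethyl for Methyl on a Three-Ring Acid Scaffold

The compounds below may be only part of what the source reports. "The series", "measured", "known", "first", "only" and "open" are said of these compounds alone.

Compound 1, `Cc1ccc(C(=O)c2ccc(C(=O)c3ccc(C(=O)O)cc3)cc2)cc1`, carries a carboxylic acid on one outer ring and a methyl on the other, joined through two carbonyls. In an assay on CHO cells for inhibition of 3-oxo-5-alpha-steroid 4-dehydrogenase 2 (Homo sapiens) (a higher number here means a weaker inhibitor, a lower number a stronger inhibitor), compound 1 gives 10 nM. Compound 2, `O=C(O)c1ccc(C(=O)c2ccc(C(=O)c3ccc(C(F)(F)F)cc3)cc2)cc1`, differs from it only by trifluoromethyl in place of methyl on an aromatic carbon. In this assay compound 2 gives 30 nM; the step is a 3.0-fold higher number from compound 1 to compound 2 (0.48 log units; beyond the scatter).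

Compound 3, `Cc1ccc(Cc2ccc(C(=O)c3ccc(C(=O)O)cc3)cc2)cc1`, keeps the acid and the methyl but has a different core; the difference between the core of compound 3 and the core of compound 1 is not broken down here. In this assay compound 3 gives 15 nM, which sits within the scatter of compound 1 and also within the scatter of compound 2, so no order among these three can be read from the numbers.

Compound 4, `O=C(O)c1ccc(C(=O)c2ccc(Cc3ccc(C(F)(F)F)cc3)cc2)cc1`, has not been measured. It differs from compound 3 by trifluoromethyl in place of methyl on an aromatic carbon. The place described for this change is the same, word for word, as for the change from compound 1 to compound 2, so it is the same change applied to a different core. A step of a 3.0-fold higher number from compound 3 to compound 4 (0.48 log units; beyond the scatter) is expected, because a 3.0-fold higher number from compound 1 to compound 2 (0.48 log units; beyond the scatter) was seen on the related core and the same change is made here. Compound 4 is therefore estimated at 45 nM, with a likely range from 20 nM to 110 nM in this assay.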

Compound 4, inhibition constant: 30 nM
The estimate for compound 4 lay 1.5-fold (0.18 log units) above the measured number; the measured number falls inside the stated range.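

In this assay, the change of methyl to trifluoromethyl on the core of compound 3 gives a 2.0-fold higher number from compound 3 to compound 4 (0.30 log units; within the scatter), so on this core alone the step cannot be told apart from the ordinary spread of repeated measurements. Set beside the step on the core of compound 1, the result gives no sign that the core alters the effect of this change, since the two steps do not differ by more than the scatter allows: the same change on two cores in this assay, a 3.0-fold higher number (0.48 log units; beyond the scatter) from compound 1 to compound 2 and a 2.0-fold higher number (0.30 log units; within the scatter) from compound 3 to compound 4, 1.5-fold (0.18 log units) apart, within the scatter of two such steps. For the compounds shown here, this fits the idea that the change carries over between these two cores, but it does not prove that the effect is the same on both, as only the step on the core of compound 1 stands clear of the scatter, and two cores say nothing about how the change would behave on any other core.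

The compounds shown leave open what other groups at that same place would do, such as a chlorine atom, a methoxy group or a longer chain like ethyl. Every compound shown also keeps its carboxylic acid, so the effect of an amide or an ester in its place remains unknown.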